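Swapping 3-Hydroxyphenyl for 1H-Indol-7-yl

The source may report more compounds than this note shows. Statements on the series, on what has been measured and on what is new or still open speak of the compounds shown alone.

For the measured compounds named here, in a functional assay on HepG2 cells (Homo sapiens) for cytotoxicity, read by spectrophotometry, with a stated time of 72 h (on this read-out higher numbers stand for weaker inhibition and lower numbers for stronger inhibition), compound 2 `COc1cc(-n2c(-c3cccc(O)c3)cccc2=O)cc(OC)c1OC` gives 34 nM, the only true number so far. Compound 1 `COc1cc(-n2c(-c3ccc([N+](=O)[O-])cc3)cccc2=O)cc(OC)c1OC` gives < 10 nM, which is a limit of the assay. Compound 3 `COc1cc(-n2c(-c3cccc4cc[nH]c34)cccc2=O)cc(OC)c1OC` carries 1H-indol-7-yl in place of 3-hydroxyphenyl on an aromatic carbon, next to the ring nitrogen: 1H-indol-7-yl in place of 3-hydroxyphenyl on an aromatic carbon. Going by the values given here, one measured step bears on this change, since it replaced a group on the same carbon: an at least 3.4-fold higher number from compound 1 to compound 2 (0.53 log units; beyond the scatter), which lies beyond the scatter. That single step gives no firm direction, so no step beyond the scatter is expected in this assay: a 1.1-fold lower number from compound 2 to compound 3 (0.05 log units; within the scatter). The estimated value for compound 3 is 30 nM, with an expected range of 8 nM to 120 nM.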

Compound 3, half-maximal inhibitory concentration: 2400 nM
Estimate against measurement, compound 3: 80-fold (1.90 log units) below; the measured number lies above the stated range.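

The change brings a 71-fold higher number from compound 2 to compound 3 (1.85 log units; beyond the scatter) in this assay, so the group on this carbon can matter a great deal, even though both groups count one hydrogen-bond donor and a six-membered aromatic ring of carbon only. Replacing 4-nitrophenyl brings an at least 240-fold higher number from compound 1 to compound 3 (2.38 log units; beyond the scatter) as well, and that step is only a lower bound, since compound 1 stands at a limit of the assay: the limit of < 10 nM in this assay, at which 1 of the 3 values shown sits.

The compounds shown cannot tell whether the extra five-membered ring or the loss of the hydroxyl group counts more. A plain phenyl or an aminophenyl on this carbon would help separate the two.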